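Swapping the Chain End of Compound 2

The compounds below may be only part of what the source reports. "The series", "measured", "known", "first", "only" and "open" are said of these compounds alone.

In a functional assay on MDA-MB-231 cells (Homo sapiens) for antiproliferative activity, read by MTT assay (a lower number here means a stronger inhibitor, a higher number a weaker inhibitor), compound 1 (`CC/C=C\C/C=C\C/C=C\CCCCCCCc1cc(=O)c2c(O)cc(OCOC)c(C)c2o1`) gives 6790 nM and compound 3 (`CCCCC/C=C\C/C=C\CCCCCCCC1(O)CC(=O)c2c(O)cc(OCOC)cc2O1`) gives 16100 nM as measured numbers. Compound 2 (`CCCCCCCCCCCCCCCc1cc(=O)c2c(O)c(C)c(OCOC)cc2o1`) gives > 87000 nM as a limit of the assay, not a number. Compound 4 (`CC/C=C\C/C=C\C/C=C\CCCCCCCc1cc(=O)c2c(O)c(C)c(OCOC)cc2o1`) differs from it on a saturated chain carbon, seven bonds along the chain from an aromatic carbon (a group of 10 heavy atoms (10 carbon; no ring) in place of a group of 8 heavy atoms (8 carbon; no ring), on a saturated chain carbon, seven bonds along the chain from an aromatic carbon). Among the compounds with values here, no measured step shows what this swap does in this assay on its own. A clear gain in strength is expected, with compound 1 at 6790 nM as the guide. Compound 4 may still return only a limit. The estimate gives an at least 4.3-fold lower number from compound 2 to compound 4 (0.63 log units; beyond the scatter) as the expected size of the change. For compound 4 the estimated value is 20000 nM (expected range 6000 nM to 70000 nM).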

Compound 4, half-maximal inhibitory concentration: 6790 nM
Compound 4: the middle estimate sits 2.9-fold (0.47 log units) above what was measured; the measured number falls inside the stated range.
By their numbers in this assay, from the lowest: compounds 1 and 4 (each within the scatter of the next); then compound 3. At a limit, above all of these: compound 2.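

In this assay, putting the group with 3 double bonds in place of the octyl chain end gives an at least 12-fold lower number from compound 2 to compound 4 (1.10 log units; beyond the scatter). This is the first step shown between two compounds that differ in one place, and it shows that a change on this saturated chain carbon can move the reading beyond the scatter. Its full size stays unknown because compound 2 stands at a limit of the assay, not a number: the limit of > 87000 nM in this assay, at which 1 of the 4 values shown sits.

On these data alone, what a fully saturated chain of the same length, or a chain ending in an amine or a carboxylic acid, would give remains open. The double bonds and the added length therefore cannot yet be told apart.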